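Methylamino versus dimethylamino thiazoles under a para-group swap

The source may report more compounds than this note shows. Statements on the series, on what has been measured and on what is new or still open speak of the compounds shown alone.

Compound 1 `CNc1nc(-c2cc(OC)c(OC)c(OC)c2)c(-c2ccc(C(F)(F)F)cc2)s1`, compound 2 `CNc1nc(-c2cc(OC)c(OC)c(OC)c2)c(-c2ccc(OC)cc2)s1` and compound 3 `COc1cc(-c2nc(N(C)C)sc2-c2ccc(C(F)(F)F)cc2)cc(OC)c1OC` have been measured in a functional assay on A549 cells (Homo sapiens) for antiproliferative activity, read by MTT assay, with a stated time of 72 h; a higher number here means a weaker inhibitor, a lower number a stronger inhibitor; compound 4 `COc1ccc(-c2sc(N(C)C)nc2-c2cc(OC)c(OC)c(OC)c2)cc1` has not. In this assay compound 1 gives 4570 nM and compound 2 gives 138 nM. The step of a 33-fold lower number from compound 1 to compound 2 (1.52 log units; beyond the scatter) follows the change (methoxy in place of trifluoromethyl on an aromatic carbon). For compound 3 only a limit is recorded, > 10000 nM, which is the limit of > 10000 nM in this assay, at which 1 of the 3 values shown sits. The step of an at least 2.1-fold higher number from compound 1 to compound 3 (0.34 log units; beyond the scatter) follows the change (methyl in place of hydrogen on a nitrogen on an aromatic ring), and this is also how the core of compound 3 differs from the core of compound 1. For the measured compounds named here, compound 4 differs from compound 3 by methoxy in place of trifluoromethyl on an aromatic carbon, the same change as the one made between compound 1 and compound 2, at the same place. A step of about an at least 20-fold lower number from compound 3 to compound 4 (1.30 log units; beyond the scatter) is expected, resting on a 33-fold lower number from compound 1 to compound 2 (1.52 log units; beyond the scatter). Compound 4 is estimated at 500 nM, between 120 nM and 3000 nM.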

Compound 4, half-maximal inhibitory concentration: > 10000 nM
Compound 4: only a limit was reported (the forecaster's own chance of this, stated with the estimate: 8%); at least 20-fold (1.30 log units) between middle value and limit.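

In this assay compound 4 gives > 10000 nM, which is a limit of the assay and not a number: the limit of > 10000 nM in this assay, at which 2 of the 4 values shown sit.

With compound 3 also at a limit, the step for methoxy in place of trifluoromethyl cannot be read on this core, so the drop seen on the core of compound 1 is neither confirmed nor ruled out here. The methoxy pair does show a clear loss on adding the second methyl on the nitrogen, an at least 72-fold higher number from compound 2 to compound 4 (1.86 log units; beyond the scatter), and this sets the change beside its trifluoromethyl counterpart: the same change on two cores in this assay, an at least 2.1-fold higher number (0.34 log units; beyond the scatter) from compound 1 to compound 3 and an at least 72-fold higher number (1.86 log units; beyond the scatter) from compound 2 to compound 4; the limit leaves it open whether they differ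

Going by these compounds, whether any dimethylamino compound reads below the limit remains open. Also open, on these data alone, is how an ethyl group on that nitrogen, or an unsubstituted amine, would behave with 4-methoxyphenyl in place.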